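Aryl substituent replacement on the biaryl tail of the series

This account rests on a few compounds, and the source may have more. Where it says the series, first, only, none or still open, it means among the compounds named here.

Among the compounds with values here, compound 2, `CC[C@H](C)[C@H](N)CN(C(=O)[C@@H]1C[C@H]1c1ccccc1)c1ccc(-c2ccc(NS(C)(=O)=O)cc2)cc1`, gives 1200 nM in a functional assay for agonist activity at G protein-coupled receptor 88 (Homo sapiens), read by HTRF and cAMP accumulation (on this read-out lower numbers stand for an effect already at smaller amounts and higher numbers for an effect only at larger amounts of compound), the higher of the two numbers measured so far; its nearest neighbour is compound 1, `CC[C@H](C)[C@H](N)CN(C(=O)[C@@H]1C[C@H]1c1ccccc1)c1ccc(-c2ccc(OC(F)(F)F)cc2)cc1`, which gives 170 nM in this assay. Within the data shown here, the one measured step, a 7.1-fold higher number from compound 1 to compound 2 (0.85 log units; beyond the scatter), shows that the group on the outer ring moves the read-out beyond the scatter. Compound 3, `CC[C@H](C)[C@H](N)CN(C(=O)[C@@H]1C[C@H]1c1ccccc1)c1ccc(-c2ccc(CNC)cc2)cc1`, is not yet measured; it differs from compound 2 by (methylamino)methyl in place of methanesulfonamido on an aromatic carbon. Among the measured compounds shown here, no measured step covers a (methylamino)methyl group at this position, so the direction rests only on the fact that this ring position is sensitive. The expectation for compound 3 is a number somewhat lower than that of compound 2, a step of a 2.0-fold lower number from compound 2 to compound 3 (0.30 log units; within the scatter), though within a wide band. Compound 3 is estimated at 600 nM, with a range from 150 nM to 2500 nM.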

Compound 3, half-maximal effective concentration: 6400 nM
Compound 3: the middle estimate sits 11-fold (1.03 log units) below what was measured; measured number above the stated range.
By their numbers in this assay, from the lowest: compound 1; then compound 2; then compound 3.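

In this assay the three groups read so far at this aromatic carbon spread further than the first pair showed, with a 38-fold higher number from compound 1 to compound 3 (1.58 log units; beyond the scatter) as the widest gap in the set. Exchanging methanesulfonamido for (methylamino)methyl does not recover the lost ground: the change gives a 5.3-fold higher number from compound 2 to compound 3 (0.73 log units; beyond the scatter) and so moves further from trifluoromethoxy. Both nitrogen-bearing groups therefore stand above trifluoromethoxy, no compound shown goes against that order, and nothing at hand accounts for it.

Open, on these data alone, is whether an aminomethyl or dimethylaminomethyl group would read close to compound 3, or whether a carboxylic acid would fall on either side of it. Also open, as far as these compounds go, is whether a chlorine or trifluoromethyl group at the same carbon would read close to compound 1.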